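Swapping the pyridine substituents on a thiazole acetic acid

The source may report more compounds than this note shows. Statements on the series, on what has been measured and on what is new or still open speak of the compounds shown alone.

Compound 2 `O=C(O)Cc1sc(C(c2ccc(F)cc2)c2ccc(F)cc2)nc1-c1cc(F)nc(F)c1` is the stronger of the two measured compounds here. In an in vitro functional assay on HEK285-7 cells for antagonist activity at prostaglandin D2 receptor 2 (Homo sapiens), read by BRET and beta-arrestin recruitment (on this read-out lower numbers stand for stronger inhibition and higher numbers for weaker inhibition), compound 2 gives 110 nM, whereas compound 1 `N#Cc1ccc(-c2nc(C(c3ccc(F)cc3)c3ccc(F)cc3)sc2CC(=O)O)cc1` gives 1500 nM in this assay. For the measured compounds named here, the single measured step, a 14-fold lower number from compound 1 to compound 2 (1.13 log units; beyond the scatter), shows that exchanging the aromatic group attached to the shared core can shift the number a great deal.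

Compound 3 `O=C(O)Cc1sc(C(c2ccc(F)cc2)c2ccc(F)cc2)nc1-c1ccnc(N2CCC2)c1` has not yet been measured. It differs from compound 2 by 2-(azetidin-1-yl)pyridin-4-yl in place of 2,6-difluoropyridin-4-yl on an aromatic carbon. Going by the values given here, no measured step covers this particular exchange; the only step known, a 14-fold lower number from compound 1 to compound 2 (1.13 log units; beyond the scatter), concerns a different pair of groups at the same position, so it tells only that this position matters, not which way the new group will move the number.

On that basis compound 3 is expected to stay in the general neighbourhood of compound 2, with the step of a 1.8-fold higher number from compound 2 to compound 3 (0.26 log units; within the scatter) expected to be modest but uncertain. The estimate for compound 3 in this assay is 200 nM, with a range from 40 nM to 1000 nM.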

Compound 3, half-maximal inhibitory concentration: > 100000 nM
Compound 3 was reported as a limit; the forecaster's own chance of this, stated with the estimate: 5%; at least 500-fold (2.69 log units) between middle value and limit.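

In this assay, compound 3 stands only as a limit and not as a number: the limit of > 100000 nM in this assay, at which 1 of the 3 values shown sits.

The earlier step showed that a change at this aromatic carbon could lower the number, but the swap from 2,6-difluoropyridin-4-yl to 2-(azetidin-1-yl)pyridin-4-yl moves it sharply the other way, giving an at least 900-fold higher number from compound 2 to compound 3 (2.95 log units; beyond the scatter). Since both groups contain the same kind of six-membered aromatic ring with 1 hetero atom, having that ring here is clearly not enough, and what is attached to it can decide between a clear read-out and a limit; the 2-(azetidin-1-yl)pyridin-4-yl group also compares poorly with the 4-cyanophenyl group, with an at least 66-fold higher number from compound 1 to compound 3 (1.82 log units; beyond the scatter).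

The compounds shown cannot separate the two parts of this change, the loss of the fluorines and the arrival of the azetidine ring, and they give no reason for the drop. A pyridine carrying a single fluorine and no amine, or one carrying an open-chain amine such as dimethylamino in place of the azetidine ring, would help to tell these two parts apart.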